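The source may hold more compounds than are shown below. What is called first, only, known or untested is meant among the compounds shown, and "the series" means these compounds.

Of the compounds shown here, three sharing one core have so far been tested in an ADME assay on Vero cells (Chlorocebus sabaeus) for cytotoxicity, read by resazurin assay, with a stated time of 3 days; on this read-out lower numbers stand for stronger inhibition and higher numbers for weaker inhibition. Compound 1 `CN(C)c1cc2[nH]c(C3CCCCC3)nc2cc1NC(=O)c1ccc(Br)cc1` reaches only the limit of this assay, > 100 ug/mL. Compound 2 `O=C(Nc1cc2nc(C3CCCCC3)[nH]c2cc1N1CCCC1)c1ccc(Br)cc1` likewise gives no number in this assay but a limit, > 100 ug/mL. Compound 3 `CCCOCC(=O)Nc1cc2nc(C3CCCCC3)[nH]c2cc1N(CC)CC` also sits at a limit in this assay, > 100 ug/mL. Within the data shown here, the single change of pyrrolidin-1-yl in place of dimethylamino on an aromatic carbon gives a step, a step that the two limits leave unreadable from compound 1 to compound 2, that the two limits leave unreadable. Compound 2 thus stands where every tested compound stands, at the limit of > 100 ug/mL in this assay, at which 3 of the 3 values shown sit, with no measurable cytotoxicity inside the tested range.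

Compound 4 `COCCOC(=O)Nc1cc2nc(C3CCCCC3)[nH]c2cc1N1CCCC1` differs from compound 2 in one place: 2-methoxyethoxy in place of 4-bromophenyl on a carbonyl carbon. Among the measured compounds shown here, no measured step bears on this change, so the expectation rests only on the three limits already seen. Compound 4 is therefore expected to give about 100 ug/mL, within 60 ug/mL to 160 ug/mL, most likely again reported only as a limit. The estimated step of a number no higher from compound 2 to compound 4 (the limit leaves the size open) means no change beyond the scatter.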

Compound 4, half-maximal inhibitory concentration: > 100 ug/mL
Compound 4 was reported as a limit; the forecaster's own chance of this, stated with the estimate: 85%; the middle value sits exactly at the limit.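

Compound 2 and compound 4 are both reported only as limits in this assay, and the step between them cannot be read. The compounds shown leave open at what concentration any of them would show cytotoxicity, and whether 2-methoxyethoxy in place of 4-bromophenyl changes it.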